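The source may hold more compounds than are shown below. What is called first, only, known or untested is meant among the compounds shown, and "the series" means these compounds.

In this assay the two measured compounds stand as follows:
compound 1 `C=CCNC(=S)NCCCCn1nc(-c2ccccc2)ccc1=O` gives 78.6 mg/kg in a functional assay on the whole organism with Rattus norvegicus as the target; on this read-out higher numbers stand for an effect only at larger amounts of compound and lower numbers for an effect already at smaller amounts
compound 2 `C/N=C(\NC#N)NCCCCn1nc(-c2ccccc2)ccc1=O` gives 38.5 mg/kg in this assay

Within the data shown here, compound 2 thus holds the lowest of the two numbers, and its only neighbour is compound 1, separated from it by the one known step, a 2.0-fold lower number from compound 1 to compound 2 (0.31 log units; beyond the scatter). Compound 3 `C/N=C(\S)NCCCn1nc(-c2ccccc2)ccc1=O` differs from compound 2 in another way: a group of 5 heavy atoms (2 carbon, 2 nitrogen, 1 sulfur; no ring) in place of a group of 8 heavy atoms (4 carbon, 4 nitrogen; no ring), on a saturated chain carbon, three bonds along the chain from an aromatic nitrogen. Among the measured compounds shown here, no measured step covers this exact exchange. The step from compound 1 to compound 2 bears on it only in part, in that the group leaving there also carried a sulfur and the group entering there, as in compound 2, was made of carbon and nitrogen alone; that step was modest and beyond the scatter. Compound 3 reverses that direction and also shortens the chain, so a modest move back toward a higher number is expected, a 1.6-fold higher number from compound 2 to compound 3 (0.19 log units; within the scatter), though a result within the scatter of compound 2 cannot be ruled out. For compound 3 the estimate in this assay is 60 mg/kg, with a range from 25 mg/kg to 150 mg/kg.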

Compound 3, dose for half-maximal effect: 58 mg/kg
Beside the measured number, compound 3's estimate is 1.0-fold (0.01 log units) above it, within the range that was stated.
By their numbers in this assay, from the lowest: compounds 2, 3 and 1 (each within the scatter of the next, the first and the last beyond it).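

Both new steps at this position, on a saturated chain carbon, three bonds along the chain from an aromatic nitrogen, stay within the scatter in this assay: there is a 1.5-fold higher number from compound 2 to compound 3 (0.18 log units; within the scatter) and also a 1.4-fold lower number from compound 1 to compound 3 (0.13 log units; within the scatter) on the same read-out. Compound 3, with its group of 5 heavy atoms, therefore cannot be told apart from either compound 2 or compound 1, even though those two compounds lie beyond the scatter of each other. This shows that the exchange at this position can remove a group of 8 heavy atoms, whether it carries sulfur as in compound 1 or none as in compound 2, with no difference that can be read, and no measurement at hand offers an explanation for this result.

Because each step changes the end group and the chain together, the compounds shown do not separate the contribution of either. Also open, on these data alone, is how this assay would read a primary amine or a carboxylic acid at the end of the chain, or a longer chain carrying the group of compound 3.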